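Cytotoxicity notes on the aryl ester series, compound 4 pending

The compounds below may be only part of what the source reports. "The series", "measured", "known", "first", "only" and "open" are said of these compounds alone.

Measured so far:
- compound 1 `COC(=O)c1c(F)cccc1OC(=O)COc1cc(O)c2c(=O)cc(-c3ccccc3)oc2c1`: 319000 nM
- compound 2 `COC(=O)c1cc(Cl)ccc1OC(=O)COc1cc(O)c2c(=O)cc(-c3ccccc3)oc2c1`: > 436000 nM, a limit of the assay
- compound 3 `COC(=O)c1cc(Br)ccc1OC(=O)COc1cc(O)c2c(=O)cc(-c3ccccc3)oc2c1`: > 450000 nM, a limit of the assay

Going by the values given here, in an ADME assay on cells (T-cell, Mus musculus, strain BALB/c) for cytotoxicity, read by MTT assay, with a stated time of 48 h (on this read-out higher numbers stand for lower toxicity in this test and lower numbers for higher toxicity in this test), compound 1 gives 319000 nM, the only actual number among the three measured entries. Compound 2 reaches only a limit of this assay, > 436000 nM. Compound 3 likewise reaches only a limit, > 450000 nM. The steps that start from compound 1 are therefore floors: an at least 1.3-fold higher number from compound 1 to compound 2 (0.13 log units; that floor lies within the scatter), and an at least 1.4-fold higher number from compound 1 to compound 3 (0.14 log units; that floor lies within the scatter). Between the two halogen analogues a step that the two limits leave unreadable from compound 2 to compound 3.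

Compound 4 `COC(=O)c1cc(C)ccc1OC(=O)COc1cc(O)c2c(=O)cc(-c3ccccc3)oc2c1` changes the same group on the oxygen next to a carbonyl group that compounds 2 and 3 also varied: a group of 11 heavy atoms (9 carbon, 2 oxygen; one six-membered aromatic ring of carbon only) in place of a group of 11 heavy atoms (8 carbon, 2 oxygen, 1 fluorine; one six-membered aromatic ring of carbon only), on an oxygen next to a carbonyl group. Both measured exchanges of this group gave floors within the scatter, so no step beyond the scatter is expected here either, with a fair chance that compound 4 also ends at a limit of this assay. For compound 4 the expected value in this assay is 400000 nM, with a range from 200000 nM to 800000 nM. That estimate means a 1.3-fold higher number from compound 1 to compound 4 (0.10 log units; within the scatter).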

Compound 4, half-maximal cytotoxic concentration: 306000 nM
For compound 4 the middle estimate is 1.3-fold (0.12 log units) above the measured one; the measured number falls inside the stated range.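

In this assay, going by these compounds alone, compound 4 gives a second actual number for this group on an oxygen next to a carbonyl group, and a 1.0-fold lower number from compound 1 to compound 4 (0.02 log units; within the scatter); this is the first exchange here with both ends readable. Against the halogen analogues only floors are available: an at least 1.4-fold lower number from compound 3 to compound 4 (0.16 log units; that floor lies within the scatter), and an at least 1.4-fold lower number from compound 2 to compound 4 (0.15 log units; that floor lies within the scatter). Compound 2 and compound 3 each stand only at a limit of the assay, so neither step gives a true size, and no exchange shown at this place moves the read-out beyond the scatter.

Going by these compounds, whether the methyl compound truly separates from the chloro and bromo compounds stays open without actual numbers for compound 2 and compound 3. Also open, on these data alone, is how an amine or a carboxylic acid on this aryl ring would read in this assay.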